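The source may report more compounds than this note shows. Statements on the series, on what has been measured and on what is new or still open speak of the compounds shown alone.

Measured compounds in hand:
compound 1 `CC(=O)c1ccc(NC(=O)CCCCCCNC(=O)C(O)(O)C(F)(F)F)cc1` — 12100 nM
compound 2 `O=C(CCCCCCNC(=O)C(O)(O)C(F)(F)F)Nc1nc2ccc(Br)cc2s1` — 10300 nM
compound 3 `NC(=O)C(=O)NCCCCCC(=O)Nc1ccccc1` — a limit only, > 100000 nM

In a functional assay on HCT-116 cells (Homo sapiens) for inhibition, read by colorimetric assay, with a stated time of 3 days (on this read-out lower numbers stand for stronger inhibition and higher numbers for weaker inhibition), compound 1 gives 12100 nM; this is the highest of the two numbers shown, yet compound 2, at 10300 nM, sits within the scatter of it, so the two cannot be told apart. For compound 3 this assay reports no number but a limit, > 100000 nM, one of the values sitting at the limit of > 100000 nM in this assay, at which 1 of the 3 values shown sits. Going by the values given here, compound 3 carries no trifluoromethyl diol and no substituent on its aryl ring, and no step from it to the others is counted.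

The next compound, compound 4 `COc1ccc(NC(=O)CCCCCCNC(=O)C(O)(O)C(F)(F)F)cc1`, keeps the whole chain of compound 1 and changes only the aryl substituent: methoxy in place of acetyl on an aromatic carbon. Among the compounds with values here, with no measured step of this kind to lean on, the expectation is a step no larger than the scatter, in either direction, a 1.2-fold higher number from compound 1 to compound 4 (0.06 log units; within the scatter). Compound 4 is therefore estimated at 14000 nM in this assay, with a range from 5000 nM to 45000 nM.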

Compound 4, half-maximal inhibitory concentration: 4520 nM
Compound 4: middle estimate off by 3.1-fold (0.49 log units), on the high side, and the stated range ends above it.
By their numbers in this assay, from the lowest: compound 4; then compounds 2 and 1 (each within the scatter of the next). At a limit, above all of these: compound 3.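

With the chain held constant, the aryl substituent on the aromatic carbon para to a large group now has a measured effect in this assay: going from 4-acetylphenyl to 4-methoxyphenyl gives a 2.7-fold lower number from compound 1 to compound 4 (0.43 log units; beyond the scatter) in this series. Going by these compounds alone, this is the first comparison between compounds that differ in one place, and the step lies beyond the scatter, although it is modest. Nothing shown gives a cause for this step.

Still open, as far as these compounds go, is whether an amine or a carboxylic acid at this position would follow methoxy or acetyl, and whether the step would hold on a longer chain. The share of the trifluoromethyl diol in the read-out also remains open: no pair shown differs in that group alone.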